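Halogen for isopropyl on the triazole-bound phenyl ring

The source may hold more compounds than are shown below. What is called first, only, known or untested is meant among the compounds shown, and "the series" means these compounds.

Measured compounds:
- compound 1, `CC(C)c1ccc(-n2nc(-c3ccc(C(F)(F)F)cc3O)nc2-c2ccccc2O)cc1`: 100%
- compound 2, `Oc1cc(C(F)(F)F)ccc1-c1nc(-c2ccccc2O)n(-c2ccc(F)cc2)n1`: 86.7%
- compound 3, `Oc1cc(C(F)(F)F)ccc1-c1nc(-c2ccccc2O)n(-c2ccc(Br)cc2)n1`: 89.8%

In a functional assay on PC-12 cells (Rattus norvegicus) for cytotoxicity, read by MTT assay, with stated times of 2 h and 24 h, tested at 5 uM (a higher number here means a stronger effect of the compound at the concentration tested, a lower number a weaker effect), compound 1 gives 100%, the highest of the three numbers; compound 3 is its nearest neighbour and compound 2 the furthest, both beyond the scatter. The unmeasured compound 4, `Oc1cc(C(F)(F)F)ccc1-c1nc(-c2ccccc2O)n(-c2cccc(Cl)c2)n1`, differs from compound 1 in one place: 3-chlorophenyl in place of 4-isopropylphenyl on an aromatic nitrogen. For the measured compounds named here, two measured steps bear on this change, since each replaces the isopropyl group with a halogen on that ring. The change fluoro in place of isopropyl gave a number 13.3 percentage points lower from compound 1 to compound 2 (beyond the scatter), and bromo in place of isopropyl gave a number 10.2 percentage points lower from compound 1 to compound 3 (beyond the scatter). Between the two halogens themselves, a number 3.1 percentage points higher from compound 2 to compound 3 (within the scatter). Chloro in place of isopropyl, though on a different ring carbon, is therefore expected to produce a modest step downward from compound 1 to compound 4, of a size comparable to the two measured halogen steps, that is a number 12 percentage points lower from compound 1 to compound 4 (beyond the scatter). Compound 4 is thus estimated at 88%, within a range from 75% to 98%.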

Compound 4, a percentage reported as activity, at one concentration (the size of the read-out at that concentration, not a potency): 92.7%
Estimate against measurement, compound 4: 4.7 percentage points below; low and high end bracket the measured number.
By their numbers in this assay, from the lowest: compounds 2, 3, 4 and 1 (each within the scatter of the next, the first and the last beyond it).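

In this assay, for the compounds shown here, 3-chlorophenyl in place of 4-isopropylphenyl on the aromatic nitrogen gives a number 7.3 percentage points lower from compound 1 to compound 4 (within the scatter) and is the first halogen-bearing ring here whose step from compound 1 stays within the scatter. Set against the other halogen compounds, 3-chlorophenyl in place of 4-bromophenyl gives a number 2.9 percentage points higher from compound 3 to compound 4 (within the scatter) and in place of 4-fluorophenyl gives a number 6 percentage points higher from compound 2 to compound 4 (within the scatter) in the same read-out. Compound 4 therefore cannot be separated from any of the other three compounds, even though compound 1 stands apart from compound 2 and compound 3. Nothing available explains these numbers.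

As far as these compounds go, what a 4-chlorophenyl group would give remains open, so the choice of halogen and the ring carbon that carries it cannot be told apart. Also open, from the compounds shown here alone, is how an amine or a carboxylic acid on this ring would behave.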